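The source may report more compounds than this note shows. Statements on the series, on what has been measured and on what is new or still open speak of the compounds shown alone.

Series notes. Two members have been run in a functional assay on NB-4 cells (Homo sapiens) for inhibition, read by MTT assay, with a stated time of 48 h; on this read-out lower numbers stand for stronger inhibition and higher numbers for weaker inhibition. Compound 1 `Cc1cc2c(cc1C(=O)c1ccc(C(=O)OCCCCOC(=O)c3ccc(C(=O)Nc4ccc5c(c4)C(C)(C)CCC5(C)C)cc3)cc1)C(C)(C)CCC2(C)C`, a dimeric structure carrying two copies of the shared core, gives 147000 nM in this assay. Compound 2 `CCCC(=O)OCCCCOC(=O)c1ccc(C(=O)Nc2ccc3c(c2)C(C)(C)CCC3(C)C)cc1` gives 23200 nM in this assay, the lower of the two numbers, with compound 1 standing a long way above it, well beyond the scatter. The next member, compound 3 `CCCC(CCC)C(=O)OCCCCOC(=O)c1ccc(C(=O)Nc2ccc3c(c2)C(C)(C)CCC3(C)C)cc1`, keeps everything of compound 2 except the ester terminus: 1-propylbutyl in place of propyl on a carbonyl carbon. Within the data shown here, no pair of measured compounds differs in one place, so no measured step shows what this kind of change does here. Compound 3 is expected to stay close to compound 2, with the step of a 1.2-fold lower number from compound 2 to compound 3 (0.06 log units; within the scatter) in this assay estimated as none beyond the scatter. The value for compound 3 in this assay is accordingly estimated at 20000 nM, within a range of 8000 nM to 60000 nM.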

Compound 3, half-maximal inhibitory concentration: > 1000000 nM
Compound 3: a limit, no number (the forecaster's own chance of this, stated with the estimate: 10%); middle value at least 50-fold (1.69 log units) from the limit.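

In this assay, among these compounds, 1-propylbutyl in place of propyl on a carbonyl carbon gives the first single-place step: an at least 43-fold higher number from compound 2 to compound 3 (1.63 log units; beyond the scatter). Among the compounds shown here, the ester terminus is therefore not a neutral place in this assay, since this one change moves the read-out far beyond the scatter, which no earlier pair could show. The reading for compound 3 is a limit and not a number, so the step has a lower bound but no known size: the limit of > 1000000 nM in this assay, at which 1 of the 3 values shown sits.

The compounds shown cannot separate the effect of chain length from that of branching, as a straight heptyl chain or a tert-butyl group on the same carbonyl carbon would. Going by these compounds, how an amine or a carboxylic acid at this terminus would read in this assay also stays open.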